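Moving the methoxy group: compound 3 to compound 4

The compounds below may be only part of what the source reports. "The series", "measured", "known", "first", "only" and "open" are said of these compounds alone.

Measured compounds:
- Compound 1, `COc1ccc(Nc2nnc(Nc3nc(-c4ccc(Cl)cc4)cs3)s2)cc1`, 300 mg/kg
- Compound 2, `COc1ccc(Nc2nnc(Nc3nc(-c4ccc(Br)cc4)cs3)s2)cc1`, 100 mg/kg
- Compound 3, `COc1ccccc1Nc1nnc(Nc2nc(-c3ccccc3)cs2)s1`, 300 mg/kg

In a functional assay on the whole organism (strain albino) with Mus musculus as the target, in the maximal electroshock model, with a stated time of 4 h (a higher number here means that more compound is needed for the effect, a lower number that less compound is needed), compound 3 gives 300 mg/kg. It is level with compound 1 at the digits printed, and these two together sit at the highest number of the three; compound 2 gives the lowest number, reached through a 3.0-fold lower number from compound 1 to compound 2 (0.48 log units; beyond the scatter).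

Compound 4, `COc1ccc(Nc2nnc(Nc3nc(-c4ccccc4)cs3)s2)cc1`, is not yet measured. It differs from compound 3 in one place: 4-methoxyphenyl in place of 2-methoxyphenyl on a nitrogen on an aromatic ring. Among the measured compounds shown here, the only measured step, bromo in place of chloro, concerns a different part of the molecule and says nothing about moving the methoxy group. For the measured compounds named here, compound 1 and compound 2 carry the 4-methoxyphenyl group that enters here, and their numbers bracket compound 3 between one level with it and one below it, but without a direct comparison no step in this assay beyond the scatter can be foreseen.

Compound 4 is therefore expected at 300 mg/kg, with a range of 100 mg/kg to 600 mg/kg, which amounts to an expected step of no change at the digits printed from compound 3 to compound 4 (within the scatter).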

Compound 4, minimum effective dose: 100 mg/kg
Compound 4: the middle estimate sits 3.0-fold (0.48 log units) above what was measured; the measured number falls inside the stated range.
By their numbers in this assay, from the lowest: compounds 2 and 4 (each within the scatter of the next); then compounds 1 and 3 (each within the scatter of the next).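

In this assay, exchanging 2-methoxyphenyl for 4-methoxyphenyl keeps the same atoms joined differently, yet it changes the result (a 3.0-fold lower number from compound 3 to compound 4 (0.48 log units; beyond the scatter)), so where the methoxy group sits on this ring matters even when nothing is added or removed. Compound 4 also provides the unsubstituted comparison for the two halogens while 4-methoxyphenyl stays fixed: hydrogen in place of bromo leaves the number level (no change at the digits printed from compound 2 to compound 4 (within the scatter)), whereas hydrogen in place of chloro lowers it (a 3.0-fold lower number from compound 1 to compound 4 (0.48 log units; beyond the scatter)), so only chloro goes with a higher dose than hydrogen. Nothing measured here offers a reason for these differences.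

Going by these compounds, whether an amine or a longer chain such as ethoxy in place of the methoxy group would keep the lower number remains open. Also open, on these data alone, is whether chloro and bromo would behave the same way alongside 2-methoxyphenyl.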